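Tail-group swap on the shared core: an amine replaces sulfinyl

This account rests on a few compounds, and the source may have more. Where it says the series, first, only, none or still open, it means among the compounds named here.

Compound 1 `N=c1sc2cc(OC(F)(F)F)ccc2n1CCS(N)(=O)=O`: 6 mg/kg
Compound 2 `CCSCCn1c(=N)sc2cc(OC(F)(F)F)ccc21`: 2.2 mg/kg
Compound 3 `C[S+]([O-])CCn1c(=N)sc2cc(OC(F)(F)F)ccc21`: 1.1 mg/kg

In a functional assay on the whole organism with Rattus norvegicus as the target (a higher number here means that more compound is needed for the effect, a lower number that less compound is needed), compound 3 gives the lowest number of the three, though one of the two steps that lead to it, a 2.0-fold lower number from compound 2 to compound 3 (0.30 log units; within the scatter), is within the scatter, while the other, a 5.5-fold lower number from compound 1 to compound 3 (0.74 log units; beyond the scatter), is beyond it. Compound 4 `CN(C)CCCn1c(=N)sc2cc(OC(F)(F)F)ccc21` changes the same position once more: a group of 4 heavy atoms (3 carbon, 1 nitrogen; no ring) in place of a group of 3 heavy atoms (1 carbon, 1 oxygen, 1 sulfur; no ring), on a saturated chain carbon, two bonds along the chain from an aromatic nitrogen. Going by the values given here, the earlier changes at this spot, a 2.7-fold lower number from compound 1 to compound 2 (0.44 log units; beyond the scatter) and a 5.5-fold lower number from compound 1 to compound 3 (0.74 log units; beyond the scatter), were both modest, and no measured compound carries an amine there, so the new group is untested. A step of a 1.8-fold higher number from compound 3 to compound 4 (0.26 log units; within the scatter) is therefore expected, most likely within the scatter. Compound 4 is estimated at 2 mg/kg, with a range of 0.7 mg/kg to 6 mg/kg.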

Compound 4, dose for half-maximal effect: 9 mg/kg
Beside the measured number, compound 4's estimate is 4.5-fold (0.65 log units) below it; the whole stated range lies below it.
By their numbers in this assay, from the lowest: compounds 3 and 2 (each within the scatter of the next); then compounds 1 and 4 (each within the scatter of the next).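

Going by these compounds alone, until now, no step at this position had raised the number in this assay. Within the data shown here, the (dimethylamino)methyl group is the first to do so, with an 8.2-fold higher number from compound 3 to compound 4 (0.91 log units; beyond the scatter) and a 4.1-fold higher number from compound 2 to compound 4 (0.61 log units; beyond the scatter), so this position does respond to the choice of group. The advantage that compounds 2 and 3 held over the sulfamoyl compound is also gone, as a 1.5-fold higher number from compound 1 to compound 4 (0.18 log units; within the scatter) shows, and no measurement here explains this result. Going by these compounds, it remains open whether the amine nitrogen or the longer chain matters more. A shorter chain carrying the dimethylamino group, or a ring amine such as morpholine, would help separate the two.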